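Series notes: the step from compound 3 to compound 4

The source may hold more compounds than are shown below. What is called first, only, known or untested is meant among the compounds shown, and "the series" means these compounds.

Measured values in an assay on CHO-K1 cells for displacement of a labelled ligand from prostaglandin E2 receptor EP1 subtype (Homo sapiens); a lower number here means a stronger inhibitor, a higher number a weaker inhibitor:
compound 1 `Cc1cc(C(=O)Nc2cccc(F)c2)nn1Cc1cc(Cl)ccc1OCc1ccccc1`: 200 nM
compound 2 `Cc1cc(C(=O)NCc2ccccc2)nn1Cc1cc(Cl)ccc1OCc1ccccc1`: 39.8 nM
compound 3 `Cc1cc(NC(=O)C2CCCC2)nn1Cc1cc(Cl)ccc1OCc1ccccc1`: 15.9 nM

Compound 3 stands lowest of the three numbers. The measured steps are a 5.0-fold lower number from compound 1 to compound 2 (0.70 log units; beyond the scatter), a 13-fold lower number from compound 1 to compound 3 (1.10 log units; beyond the scatter) and a 2.5-fold lower number from compound 2 to compound 3 (0.40 log units; beyond the scatter), each of them beyond the scatter. They exchange a 3-fluorophenyl for a benzyl on the amide-type nitrogen, or exchange an arylcarbamoyl or benzylcarbamoyl group for a (cyclopentylcarbonyl)amino group on the aromatic carbon.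

Compound 4 `Cc1cc(NC(=O)OC(C)(C)C)nn1Cc1cc(Cl)ccc1OCc1ccccc1` keeps the acylamino arrangement of compound 3 and changes only the group on the carbonyl carbon: tert-butoxy in place of cyclopentyl on a carbonyl carbon. Going by the values given here, none of the measured steps varies this position, so there is no direct precedent for the size or the direction of the change in this assay. Among the compounds with values here, the only guide is that the acylamino arrangement itself gives the lowest number so far, and a change of the five-heavy-atom group on the carbonyl carbon from a ring to a branched chain is expected to move the number by less than the measured steps did. Compound 4 is therefore estimated to give 32 nM, with a range of 10 nM to 100 nM, which means an expected step of a 2.0-fold higher number from compound 3 to compound 4 (0.30 log units; within the scatter), possibly within the scatter.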

Compound 4, half-maximal inhibitory concentration: 25.1 nM
Compound 4: middle estimate off by 1.3-fold (0.11 log units), on the high side, within the range that was stated.
By their numbers in this assay, from the lowest: compounds 3, 4 and 2 (each within the scatter of the next, the first and the last beyond it); then compound 1.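

In this assay, going by these compounds alone, the group on the carbonyl carbon is varied for the first time here, and the exchange of cyclopentyl for tert-butoxy stays within the scatter (a 1.6-fold higher number from compound 3 to compound 4 (0.20 log units; within the scatter)), so the two groups cannot be told apart at this position. This pair therefore shows that neither the carbocyclic ring nor an all-carbon group is needed on the carbonyl carbon to stay level with compound 3, at least when the entering group is tert-butoxy. On the aromatic carbon, (tert-butoxycarbonyl)amino cannot be separated from benzylcarbamoyl (a 1.6-fold lower number from compound 2 to compound 4 (0.20 log units; within the scatter)) but stands clearly apart from (3-fluorophenyl)carbamoyl (an 8.0-fold lower number from compound 1 to compound 4 (0.90 log units; beyond the scatter)), which leaves compound 1 alone at the high end of the series. No measurement is available to explain these results.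

The compounds shown leave open how far this position accepts other groups, since cyclopentyl and tert-butoxy both carry the same count of heavy atoms and a methyl, a phenyl, a dimethylamino group or a longer chain on the carbonyl carbon could behave differently. Also open, from the compounds shown here alone, is whether a carboxylic acid or a basic amine at the end of such a chain would keep the number in this range.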